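The source may report more compounds than this note shows. Statements on the series, on what has been measured and on what is new or still open speak of the compounds shown alone.

Compound 2 `CCN(CC)c1cc2[nH]c(C3CCCCC3)nc2cc1NC(=O)OCCOCCOC` is one of three compounds tested in an ADME assay on Vero cells (Chlorocebus sabaeus) for cytotoxicity, read by resazurin assay, with a stated time of 3 days (on this read-out lower numbers stand for stronger inhibition and higher numbers for weaker inhibition), and in that assay compound 2 gives > 100 ug/mL, which is a limit of the assay rather than a number. Compound 1 `CN(C)c1cc2[nH]c(C3CCCCC3)nc2cc1NC(=O)c1ccccc1` likewise gives > 100 ug/mL, a limit. Compound 3 `COc1ccc(C(=O)Nc2cc3nc(C4CCCCC4)[nH]c3cc2N(C)C)cc1` gives > 100 ug/mL, again a limit, so the step that the two limits leave unreadable from compound 1 to compound 3 cannot be read. The common ground is the limit of > 100 ug/mL in this assay, at which 3 of the 3 values shown sit. Compound 4 `CCCC(C)OC(=O)Nc1cc2nc(C3CCCCC3)[nH]c2cc1N(CC)CC` differs from compound 2 by 1-methylbutyl in place of 2-(2-methoxyethoxy)ethyl on an oxygen next to a carbonyl group. Going by the values given here, no measured step touches the oxygen next to the carbonyl group, so nothing sets a direction. Since every value shown sits at the same limit, compound 4 is expected to give 150 ug/mL, ranging from 60 ug/mL to 400 ug/mL. The expected step is therefore a step that the limit leaves unreadable from compound 2 to compound 4, most likely reported again only as a limit.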

Compound 4, half-maximal inhibitory concentration: > 100 ug/mL
Compound 4 ended at the assay's limit; the forecaster's own chance of this, stated with the estimate: 85%; the middle value lies beyond the limit too.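

In this assay, going by these compounds alone, the values of compound 2 and compound 4 are both limits, so no step between them can be read. The compounds shown leave open whether any change to the shared core would bring a reading inside the measurable range.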